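This account rests on a few compounds, and the source may have more. Where it says the series, first, only, none or still open, it means among the compounds named here.

Working notes on the series: compound 1 `CC(C)c1cc2c3c(c1OC(=O)CCl)OC(=O)[C@@]31CCCC(C)(C)[C@@H]1CC2` and compound 2 `CC(C)c1cc2c3c(c1OC(=O)c1ccccc1)OC(=O)[C@@]31CCCC(C)(C)[C@@H]1CC2` differ only in the group on a carbonyl carbon. In an ADME assay on HepG2 cells (Homo sapiens) for cytotoxicity, read by neutral red uptake, with a stated time of 24 h (a lower number here means a stronger inhibitor, a higher number a weaker inhibitor), compound 1 gives 203000 nM and compound 2 gives 510000 nM, which makes compound 2 the higher of the two numbers.

Compound 3 `CC(C)c1cc2c3c(c1OC(=O)Cc1c[nH]c4ccccc14)OC(=O)[C@@]31CCCC(C)(C)[C@@H]1CC2` is changed at that same place, starting from compound 2: (1H-indol-3-yl)methyl in place of phenyl on a carbonyl carbon. In words, (1H-indol-3-yl)methyl replaces phenyl on a carbonyl carbon.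

For the measured compounds named here, the only measured step that bears on this is a 2.5-fold higher number from compound 1 to compound 2 (0.40 log units; beyond the scatter), a modest one, with phenyl in place of chloromethyl on a carbonyl carbon. Going by the values given here, it involves a different pair of groups, and no measured compound carries (1H-indol-3-yl)methyl, so neither its size nor its direction carries over directly. Among the compounds with values here, with only that modest step a 2.5-fold higher number from compound 1 to compound 2 (0.40 log units; beyond the scatter) as a guide, no step beyond the scatter is expected in this assay, and no direction is favoured. The estimated step is a 1.3-fold lower number from compound 2 to compound 3 (0.11 log units; within the scatter). For compound 3 the estimate is 400000 nM, with an expected range of 150000 nM to 900000 nM.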

Compound 3, half-maximal inhibitory concentration: 251000 nM
Estimate against measurement, compound 3: 1.6-fold (0.20 log units) above; the measured number falls inside the stated range.
By their numbers in this assay, from the lowest: compounds 1 and 3 (each within the scatter of the next); then compound 2.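

The group on the carbonyl carbon can shift the number in either direction in this assay: alongside the earlier rise there is now a 2.0-fold lower number from compound 2 to compound 3 (0.31 log units; beyond the scatter), which leaves compound 2 alone at the high end of the three compounds. The two non-aromatic-to-aromatic comparisons do not behave alike, since a 1.2-fold higher number from compound 1 to compound 3 (0.09 log units; within the scatter) shows that a much larger group with two aromatic rings and a hydrogen-bond donor can read the same as chloromethyl in this assay, whereas phenyl does not. Size counted in heavy atoms therefore does not order these three compounds, as compound 3, the largest, stands with compound 1 and not with compound 2, and no measurement offered here accounts for these differences.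

The step to compound 3 changes several things at once, the added methyl link, the second ring and the ring nitrogen with its hydrogen, and phenylmethyl or an indole attached directly to the carbonyl carbon would be needed to separate them. From the compounds shown here alone, how an amine or a carboxylic acid at this place would read in this assay also stays open.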